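The source may report more compounds than this note shows. Statements on the series, on what has been measured and on what is new or still open speak of the compounds shown alone.

Measured compounds in this series:

compound 1, `O=C(Nc1ccc(Cl)cc1)Nc1ccc(Oc2ccc(-c3nccs3)cc2)cc1`, in a functional assay on A549 cells (Homo sapiens) for inhibition, read by MTT assay and WST assay, with a stated time of 72 h, tested at 10 uM (a lower number here means less inhibition of growth, a higher number more inhibition of growth at the concentration tested), compound 1 gives 17.7%
compound 2, `O=C(Nc1ccc(Oc2ccc(-c3nccs3)cc2)cc1)Nc1cccc(C(F)(F)F)c1`, in this assay compound 2 gives 71.5%
compound 3, `O=C(Nc1ccc(Oc2ccc(-c3nccs3)cc2)cc1)Nc1cc(C(F)(F)F)ccc1Cl`, in this assay compound 3 gives 75.5%

Compound 3 holds the highest number of the three, but its neighbour compound 2 sits within the scatter of it; only compound 1 lies clearly lower. The two large steps both run from compound 1: a number 53.8 percentage points higher from compound 1 to compound 2 (beyond the scatter) and a number 57.8 percentage points higher from compound 1 to compound 3 (beyond the scatter). The small one is a number 4 percentage points higher from compound 2 to compound 3 (within the scatter).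

The next compound, compound 4, `O=C(Nc1ccc(Oc2ccc(-c3nccs3)cc2)cc1)Nc1ccc(F)c(Cl)c1`, differs from compound 3 in one place: 3-chloro-4-fluorophenyl in place of 2-chloro-5-(trifluoromethyl)phenyl on an amide-type nitrogen.

The change removes the trifluoromethyl that compound 2 and compound 3 share and leaves a phenyl carrying only halogens, which brings compound 4 closer to compound 1 than to either of the higher pair. Within the data shown here, no measured step tests this exact group, so the expectation rests on the drop seen in reverse of the step from compound 1 to compound 3. A move downward beyond the scatter is expected, though not necessarily all the way back to compound 1. For compound 4 the estimated value in this assay is 40%, with a range from 15% to 68%; the estimated step is a number 35.5 percentage points lower from compound 3 to compound 4 (beyond the scatter).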

Compound 4, percent growth inhibition at one concentration: 37.3%
For compound 4 the middle estimate is 2.7 percentage points above the measured one; low and high end bracket the measured number.
By their numbers in this assay, from the lowest: compound 1; then compound 4; then compounds 2 and 3 (each within the scatter of the next).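

In this assay, among these compounds, the aryl group on the amide-type nitrogen sets the level more widely than the earlier compounds showed, with a number 38.2 percentage points lower from compound 3 to compound 4 (beyond the scatter) and a number 34.2 percentage points lower from compound 2 to compound 4 (beyond the scatter) when a trifluoromethyl-bearing phenyl gives way to 3-chloro-4-fluorophenyl. Among these four compounds, the two with trifluoromethyl stand clearly above the two whose phenyl carries only halogens, and none goes against this split, while the step between compound 2 and compound 3 remains within the scatter. Phenyl groups carrying only halogens do not form a single level either, since the change from 4-chlorophenyl gives a number 19.6 percentage points higher from compound 1 to compound 4 (beyond the scatter) and leaves compound 4 at an intermediate level; no measurement at hand explains this or the larger drops.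

The compounds shown leave open whether the chloro or the fluoro of compound 4 accounts for its rise over compound 1, as the two groups differ in both the kind and the placing of their halogens. They also leave open how a phenyl bearing a nitrile, a methoxy, an amine or a carboxylic acid would compare with the trifluoromethyl-bearing phenyl groups at this place.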